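Shrinking the Ketone Side Chain on a Shared Core

A few compounds are considered here, and "the series" means these few. Any claim that something is new, unique, unknown or untested is made for them only; others in the source may bear on it.

Three compounds of one family have been measured in an assay on HEK293 cells for positive allosteric modulation of metabotropic glutamate receptor 2 (Rattus norvegicus), read by thallium flux, with a stated time of 2.5 min; on this read-out higher numbers stand for larger maximal responses and lower numbers for smaller maximal responses:

Compound 1 `CCCC(=O)c1ccc(OCCCCOc2ccc(F)c(C(=O)O)c2)c(C)c1O` gives 87.5%
Compound 2 `CCC(=O)c1ccc(OCCCCOc2ccc(F)c(C(=O)O)c2)c(C)c1O` gives 66.6%
Compound 3 `Cc1c(OCCCCOc2ccc(F)c(C(=O)O)c2)ccc(C(=O)C(C)C)c1O` gives 74.1%

Compound 3 is second of the three on this read-out. Its nearest neighbour is compound 2, and that gap is within the usual scatter, so no order can be read between them. Compound 1 is the furthest away, and that gap is beyond the scatter.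

Compound 4 `CC(=O)c1ccc(OCCCCOc2ccc(F)c(C(=O)O)c2)c(C)c1O` differs from compound 3 in one place: methyl in place of isopropyl on a carbonyl carbon. The earlier steps shown here that alter the same group on the carbonyl carbon point the same way. Removing one carbon from that group gave a number 20.9 percentage points lower from compound 1 to compound 2 (beyond the scatter), while adding one gave a number 7.5 percentage points higher from compound 2 to compound 3 (within the scatter). Cutting the group down to methyl removes more than either step did, so a drop beyond the scatter is expected.

For compound 4 the expected step is a number 19.1 percentage points lower from compound 3 to compound 4 (beyond the scatter). Compound 4 is therefore estimated at 55%, with a range from 38% to 72%.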

Compound 4, largest response reached (reported as percent of maximum), in percent of the reference or control that the assay uses: 75.5%
Beside the measured number, compound 4's estimate is 20.5 percentage points below it; the whole stated range lies below it.
By their numbers in this assay, from the lowest: compounds 2, 3 and 4 (each within the scatter of the next); then compound 1.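

Acetyl does not lose response against the larger groups on this carbonyl carbon in this assay: the steps read a number 1.4 percentage points higher from compound 3 to compound 4 (within the scatter) and a number 8.9 percentage points higher from compound 2 to compound 4 (within the scatter). A shorter group here therefore does not by itself give a smaller maximal response, and the methyl, ethyl and isopropyl compounds cannot be told apart. Only the propyl group of compound 1 stands apart, with a number 12 percentage points lower from compound 1 to compound 4 (beyond the scatter), and no measurement shown accounts for this pattern.

Going by these compounds, whether a longer chain such as butyl, a cyclopropyl ring or an amine on the carbonyl carbon would match or pass compound 1 stays open. So does whether propyl would stand apart in the same way on any core other than the shared one.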